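This account rests on a few compounds, and the source may have more. Where it says the series, first, only, none or still open, it means among the compounds named here.

In a functional assay on PC-3 cells (Homo sapiens) for inhibition (on this read-out higher numbers stand for weaker inhibition and lower numbers for stronger inhibition), compound 1 `COc1cc2nc(N3CCN(C(=O)c4ccc(C(F)(F)F)cc4)CC3)nc(N)c2cc1OC` gives > 100000 nM, which is a limit of the assay rather than a number. Compound 2 `COc1cc2nc(N3CCN(S(=O)(=O)c4ccc(I)cc4)CC3)nc(N)c2cc1OC` gives 15000 nM in this assay. Within the data shown here, compound 2 therefore stands as the only compound with a measured number in this assay, while the one other value shown, that of compound 1, is a limit (the limit of > 100000 nM in this assay, at which 1 of the 2 values shown sits). Among the measured compounds shown here, because of the limit of > 100000 nM in this assay, at which 1 of the 2 values shown sits, the two values show only that compound 2 gives a number where compound 1 does not.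

Compound 3 `COc1cc2nc(N3CCN(S(=O)(=O)c4ccc(OC(F)(F)F)cc4)CC3)nc(N)c2cc1OC` has not yet been measured. It differs from compound 2 as trifluoromethoxy in place of iodo on an aromatic carbon on the same shared core. For the measured compounds named here, with only one measured number and no measured step between compounds that differ in one place, the step is expected to be a 1.3-fold higher number from compound 2 to compound 3 (0.12 log units; within the scatter), which is taken to lie within the usual scatter of repeated measurements and in no particular direction. On that basis compound 3 is expected to give about 20000 nM in this assay, with an estimated range from 5000 nM to 80000 nM.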

Compound 3, half-maximal inhibitory concentration: 25000 nM
Estimate against measurement, compound 3: 1.3-fold (0.10 log units) below; measured number inside the range.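

Read as a single step in this assay, trifluoromethoxy in place of iodo on an aromatic carbon gives a 1.7-fold higher number from compound 2 to compound 3 (0.22 log units; within the scatter), the first step on the shared core that can be read. A group of 5 heavy atoms with 1 hydrogen-bond acceptor thus enters for one of 1 heavy atom with none, on a six-membered aromatic ring of carbon only, para to a large group, and the values of the two compounds stay within the scatter of each other, so this read-out does not separate the two groups at this position. Compound 1 differs from both in more than one place and adds nothing to this step, and its value is a limit of the assay and not a number: the limit of > 100000 nM in this assay, at which 1 of the 3 values shown sits.

The compounds shown leave open whether the same holds for groups of another kind at this position, such as an amine, a carboxylic acid or a methoxy group. One pair also cannot say whether a change elsewhere on the shared core, such as a carbonyl in place of the sulfonyl alone, would move the number in this assay.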